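A few compounds are considered here, and "the series" means these few. Any claim that something is new, unique, unknown or untested is made for them only; others in the source may bear on it.

Measured so far in a functional assay on 184B5 cells (Homo sapiens) for cytotoxicity, read by sulforhodamine B assay, with a stated time of 48 h, in the presence of a further agent that is not named here; on this read-out higher numbers stand for weaker inhibition of growth and lower numbers for stronger inhibition of growth:
compound 1 `CCCCNc1ccnc2cc(Cl)ccc12` gives 19500 nM
compound 2 `CN(C)CCNc1ccnc2cc(Cl)ccc12` gives only a limit, > 20000 nM

For compound 2 the value is a limit of the assay, not a number, sitting at the limit of > 20000 nM in this assay, at which 1 of the 2 values shown sits. For the measured compounds named here, the single measured step, an at least 1.0-fold higher number from compound 1 to compound 2 (0.01 log units; that floor lies within the scatter), concerns the side chain and cannot be sized beyond its floor. Compound 3 `COc1ccc2c(NCCN(C)C)ccnc2c1` differs from compound 2 by methoxy in place of chloro on an aromatic carbon. Going by the values given here, no measured step touches this aromatic position, so nothing known here bears on it. For compound 3 the expected step is a step that the limit leaves unreadable from compound 2 to compound 3. The estimate for compound 3 is 25000 nM, between 10000 nM and 60000 nM, with a real chance that only a limit is reported again.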

Compound 3, concentration for 50% growth inhibition: > 20000 nM
Compound 3: only a limit was reported (the forecaster's own chance of this, stated with the estimate: 60%); the middle value is on the limit's open side.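

Compound 3, like compound 2, gives only a limit, so no new step can be read between compound 2 and compound 3: the limit of > 20000 nM in this assay, at which 2 of the 3 values shown sit. As far as these compounds go, whether methoxy in place of chloro on this aromatic carbon changes growth inhibition remains open.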